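Piperidinyl amides on the ring nitrogen of the series

The source may report more compounds than this note shows. Statements on the series, on what has been measured and on what is new or still open speak of the compounds shown alone.

Measured so far in an assay on AV12 cells for binding affinity to Neuropeptide Y receptor type 1 (Homo sapiens); a lower number here means a stronger inhibitor, a higher number a weaker inhibitor:
compound 1, `Cc1cccc2c1nc(COc1ccc(Cl)cc1)n2CCCC1CCNCC1` — 335 nM
compound 2, `CCOC(=O)CN1CCC(CCCn2c(COc3ccc(Cl)cc3)nc3c(C)cccc32)CC1` — 427 nM
compound 3, `Cc1cccc2c1nc(COc1ccc(Cl)cc1)n2CCCC1CCN(CCCC(=O)N2CCCCC2)CC1` — 21 nM

Compound 2 gives the highest number of the three in this assay. Its gap to compound 1 is small, a 1.3-fold higher number from compound 1 to compound 2 (0.11 log units; within the scatter), and lies within the scatter. Its gap to compound 3 is wide: a 20-fold lower number from compound 2 to compound 3 (1.31 log units; beyond the scatter). Compound 1 to compound 3 shows the same picture, a 16-fold lower number from compound 1 to compound 3 (1.20 log units; beyond the scatter).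

Compound 4, `Cc1cccc2c1nc(COc1ccc(Cl)cc1)n2CCCC1CCN(CC(=O)N2CCCCC2)CC1`, is the next step from compound 2. The change is piperidin-1-yl in place of ethoxy on a carbonyl carbon. The chain on the ring nitrogen keeps its length; only the ester end becomes the amide.

Among the measured compounds shown here, the one measured step that bears directly on this is the step from compound 2 to compound 3, which also replaces the ethoxycarbonyl end with a piperidinylcarbonyl group, though on a longer chain, and gives a large drop. The step from compound 1 to compound 3 shows the same group entering on the bare ring nitrogen with a similar large drop. For the measured compounds named here, no measured pair separates the chain length from the amide itself, so the shorter chain in compound 4 is the open question.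

A substantial drop toward compound 3 is therefore expected for compound 4, though perhaps not the full extent: a 7.1-fold lower number from compound 2 to compound 4 (0.85 log units; beyond the scatter). The estimate for compound 4 is 60 nM, with a range from 15 nM to 250 nM.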

Compound 4, inhibition constant: 136 nM
Compound 4: the middle estimate sits 2.3-fold (0.36 log units) below what was measured, within the range that was stated.
By their numbers in this assay, from the lowest: compound 3; then compound 4; then compounds 1 and 2 (each within the scatter of the next).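

In this assay the change at the carbonyl carbon can now be read with the chain length held fixed: piperidin-1-yl in place of ethoxy gives a 3.1-fold lower number from compound 2 to compound 4 (0.50 log units; beyond the scatter) and so counts on its own, without any change of chain. Chain length also counts, since shortening the link between the ring nitrogen and the amide carbonyl gives a 6.5-fold higher number from compound 3 to compound 4 (0.81 log units; beyond the scatter) and gives back much of what compound 3 gained. Set against the bare ring nitrogen, ((piperidin-1-yl)carbonyl)methyl still gives a 2.5-fold lower number from compound 1 to compound 4 (0.39 log units; beyond the scatter) as a step beyond the scatter, whereas the ester of the same chain length in compound 2 stays within the scatter of compound 1, so on this short chain the gain appears only with the amide.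

As far as these compounds go, whether a longer chain than that of compound 3 goes further remains open, as does the effect of a morpholine or dimethylamine amide or a free carboxylic acid at the chain end. Nothing on hand accounts for the effect of either the amide end or the chain length.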